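A few compounds are considered here, and "the series" means these few. Any claim that something is new, unique, unknown or untested is made for them only; others in the source may bear on it.

Of the compounds shown here, three built on one shared core have been tested in a functional assay on U-87MG ATCC cells (Homo sapiens) for cytotoxicity, read by MTT assay, with a stated time of 72 h; a higher number here means a weaker inhibitor, a lower number a stronger inhibitor. Compound 1 `CN(C)CCn1cnnc1-c1cc(Oc2ccc(NC(=O)N/N=C/c3c[nH]c4ccccc34)cc2F)ccn1` gives 690 nM in this assay. Compound 2 `COc1ccc(/C=N/NC(=O)Nc2ccc(Oc3ccnc(-c4nncn4CCN(C)C)c3)c(F)c2)c(OC)c1` gives 12600 nM, and compound 3 `CN(C)CCn1cnnc1-c1cc(Oc2ccc(NC(=O)N/N=C/c3ccc(O)c(Br)c3)cc2F)ccn1` gives 12400 nM. Among these three numbers compound 2 stands highest, though compound 3 lies within the scatter of it, while compound 1 lies well apart: the step of an 18-fold higher number from compound 1 to compound 2 (1.26 log units; beyond the scatter) and the step of an 18-fold higher number from compound 1 to compound 3 (1.25 log units; beyond the scatter) are both large, whereas the step of a 1.0-fold lower number from compound 2 to compound 3 (0.01 log units; within the scatter) is within the scatter.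

Compound 4 `Cc1cc(/C=N/NC(=O)Nc2ccc(Oc3ccnc(-c4nncn4CCN(C)C)c3)c(F)c2)cc(C)c1O` has not yet been measured. It differs from compound 2 in one place: 4-hydroxy-3,5-dimethylphenyl in place of 2,4-dimethoxyphenyl on a carbon with a double bond to nitrogen. The step that bears most directly on this change is a 1.0-fold lower number from compound 2 to compound 3 (0.01 log units; within the scatter), in which a 3-bromo-4-hydroxyphenyl also took the place of the 2,4-dimethoxyphenyl and the number barely moved. The two steps away from compound 1 show that leaving the 1H-indol-3-yl for a substituted phenyl costs a great deal, and compound 4 still carries a substituted phenyl. The expected step is therefore a 1.1-fold lower number from compound 2 to compound 4 (0.02 log units; within the scatter), which is to say no step beyond the scatter. Compound 4 is expected to give about 12000 nM in this assay, within a range from 4000 nM to 40000 nM.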

Compound 4, half-maximal inhibitory concentration: 7710 nM
The estimate for compound 4 lay 1.6-fold (0.19 log units) above the measured number; the measured number falls inside the stated range.
By their numbers in this assay, from the lowest: compound 1; then compounds 4, 3 and 2 (each within the scatter of the next).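

In this assay a third substituted phenyl now sits on the carbon with a double bond to nitrogen, and the result is again flat: a 1.6-fold lower number from compound 2 to compound 4 (0.21 log units; within the scatter) and a 1.6-fold lower number from compound 3 to compound 4 (0.21 log units; within the scatter) both leave these groups indistinguishable, even though 4-hydroxy-3,5-dimethylphenyl carries a hydrogen-bond donor that 2,4-dimethoxyphenyl lacks. The gap to the 1H-indol-3-yl also holds for this new phenyl, with an 11-fold higher number from compound 1 to compound 4 (1.05 log units; beyond the scatter) being large, so among the four compounds shown compound 1 stands alone as the strongest inhibitor, and the three phenyl groups with their different substituents all sit well apart from it. Nothing measured here explains why these phenyl groups behave alike or why the 1H-indol-3-yl stands apart.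

The compounds shown leave open which feature of the 1H-indol-3-yl matters, and a 1-methyl-1H-indol-3-yl, with a methyl on the ring nitrogen in place of its hydrogen, or a naphthyl, with no nitrogen at all, would begin to separate those features. They also leave open whether a plain unsubstituted phenyl, or a phenyl carrying an amine or a carboxylic acid, would stay with the phenyl group or come closer to compound 1.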